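A few compounds are considered here, and "the series" means these few. Any claim that something is new, unique, unknown or untested is made for them only; others in the source may bear on it.

In a functional assay on PANC-1 cells (Homo sapiens) for inhibition, read by MTT assay, with a stated time of 24 h, tested at 10 uM (a lower number here means less inhibition, a higher number more inhibition at the concentration tested (going by the name of the read-out)), compound 3 `CC(C)=CCC1Cc2c(OCCCNC(=O)c3ccc([N+](=O)[O-])cc3)cc(=O)n(CCCO)c2CC1(C)C` gives 9.1%, the lowest of the three numbers measured, though compound 2 `CC(C)=CCC1Cc2c(OCCCNS(=O)(=O)c3ccc(Cl)cc3)cc(=O)n(CCCO)c2CC1(C)C` with 9.8% and compound 1 `CCOc1cc(=O)n(CCCO)c2c1CC(CC=C(C)C)C(C)(C)C2` with 16.6% both stand within the scatter of it. Both measured steps, a number 6.8 percentage points lower from compound 1 to compound 2 (within the scatter) and a number 0.7 percentage points lower from compound 2 to compound 3 (within the scatter), fell within the scatter, so nothing on the chain has yet moved this assay. Compound 4 `CC(C)=CCC1Cc2c(OCCCOc3ccc([N+](=O)[O-])cc3)cc(=O)n(CCCO)c2CC1(C)C` differs from compound 3 by 4-nitrophenoxy in place of ((4-nitrophenyl)carbonyl)amino on a saturated chain carbon, three bonds along the chain from an oxygen on an aromatic ring. The step from compound 2 to compound 3 bears on it most, since it exchanged the group at the far end of the same chain without effect, so no step beyond the scatter is expected: a number 1.9 percentage points higher from compound 3 to compound 4 (within the scatter). For compound 4 the estimate is 11%, with a range from 2% to 22%.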

Compound 4, a percentage reported as inhibition, at one concentration (the size of the read-out at that concentration, not a potency): 0%
Estimate against measurement, compound 4: 11 percentage points above; the whole stated range lies above it.
By their numbers in this assay, from the lowest: compounds 4, 3, 2 and 1 (each within the scatter of the next, the first and the last beyond it).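

In this assay, among these compounds, a step on this chain passes the scatter for the first time: a number 16.6 percentage points lower from compound 1 to compound 4 (beyond the scatter) and so 4-nitrophenoxy at the chain end separates from the short ethoxy compound, though only modestly. The other two steps, a number 9.1 percentage points lower from compound 3 to compound 4 (within the scatter) and a number 9.8 percentage points lower from compound 2 to compound 4 (within the scatter), do not separate 4-nitrophenoxy from ((4-nitrophenyl)carbonyl)amino or ((4-chlorophenyl)sulfonyl)amino at this place. Nothing at hand explains the result. As far as these compounds go, whether an amine, a carboxylic acid or a longer chain at this place would give a number beyond the scatter of compound 1 stays open.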